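Methoxy-for-hydrogen change and tolerance across two cores

This account rests on a few compounds, and the source may have more. Where it says the series, first, only, none or still open, it means among the compounds named here.

Three compounds of the series have been through an ADME assay on MDBK cells (Bos taurus) for cytotoxicity, read by MTT assay, with a stated time of 96 h; a lower number here means that less compound is tolerated, a higher number that more compound is tolerated. Compound 3 `COc1ccc(-c2nc3cc([N+](=O)[O-])ccc3[nH]2)c(OC)c1` gives > 100000 nM, which is a limit of the assay and not a number. Compound 1 `COc1ccc(-c2nc3cc([N+](=O)[O-])ccc3[nH]2)c(OC)c1OC` gives > 100000 nM, likewise a limit. Compound 2 `COc1cc(OC)cc(-c2nc3cc(C(F)(F)F)ccc3[nH]2)c1` gives > 100000 nM, again a limit. Compound 1 arises from compound 3 by a single change, (methoxy in place of hydrogen on an aromatic carbon), and the step that the two limits leave unreadable from compound 3 to compound 1 cannot be read because of the limit of > 100000 nM in this assay, at which 3 of the 3 values shown sit.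

Compound 4 `COc1cc(-c2nc3cc(C(F)(F)F)ccc3[nH]2)cc(OC)c1OC` has not yet been measured. It arises from compound 2 by methoxy in place of hydrogen on an aromatic carbon. For the measured compounds named here, this is the same kind of change as the one from compound 3 to compound 1, not the same change: in compound 1 the entering methoxy is meta to a large group, in compound 4 it is para to a large group. The difference between the core of compound 2 and the core of compound 3 is not broken down here.

For this assay the step from compound 2 to compound 4 is expected at a step that the limit leaves unreadable from compound 2 to compound 4, set beside the unreadable a step that the two limits leave unreadable from compound 3 to compound 1. This expectation rests on compound 2, whose limit > 100000 nM sits where (the limit of > 100000 nM in this assay, at which 3 of the 3 values shown sit). Compound 4 is therefore estimated at 130000 nM in this assay. The estimated range for compound 4 runs from 50000 nM to 300000 nM, with another limit the most probable outcome. The measurement of compound 4 in this assay is awaited.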

Compound 4, half-maximal cytotoxic concentration: 18000 nM
For compound 4 the middle estimate is 7.2-fold (0.86 log units) above the measured one, and the stated range ends above it.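

In this assay, methoxy in place of hydrogen on an aromatic carbon gives an at least 5.5-fold lower number from compound 2 to compound 4 (0.74 log units; beyond the scatter), so on this core a methoxy entering para to a large group and ortho to two methoxy groups goes with less compound being tolerated. This is a single readable pair: the step of the same kind from compound 3 to compound 1 cannot be read, and its methoxy enters at a different place on a different core, so the notes do not show whether the effect of the change carries from one core to the other. The full size of the step from the core of compound 2 also stays unknown because its starting value is a limit of the assay and not a number: the limit of > 100000 nM in this assay, at which 3 of the 4 values shown sit.

Open, as far as these compounds go, is whether a different group at the same place, such as an amine, a carboxylic acid or a longer alkoxy chain, would go with a lower number in this assay as methoxy does in compound 4. Also open, from the compounds shown here alone, is whether a methoxy para to a large group on the nitro-bearing core of compound 3 would give a readable number, which would separate the place of the methoxy from the core.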